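Swapping the aryl group on a benzylidene penam ketone

The source may report more compounds than this note shows. Statements on the series, on what has been measured and on what is new or still open speak of the compounds shown alone.

Of the compounds shown here, three built on a shared core have been tested in a functional assay on OE19 cells (Homo sapiens) for cytotoxicity, read by MTT assay, with a stated time of 48 h; on this read-out lower numbers stand for stronger inhibition and higher numbers for weaker inhibition. Compound 1, `CC1(C)S[C@@H]2/C(=C\C(=O)c3ccc(C(F)(F)F)cc3)C(=O)N2[C@H]1C(=O)OC(c1ccccc1)c1ccccc1`, gives 15600 nM, the lowest of the three numbers. Compound 2, `CC1(C)[C@H](C(=O)OC(c2ccccc2)c2ccccc2)N2C(=O)/C(=C/C(=O)c3ccccc3)[C@H]2S1(=O)=O`, gives 53100 nM, and compound 3, `COC(=O)/C=C1\C[C@H]2SC(C)(C)[C@H](C(=O)OC(c3ccccc3)c3ccccc3)N2C1=O`, gives 99700 nM; both of these gaps to compound 1 lie beyond the usual scatter, so compound 1 reads as the strongest of the measured set.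

Compound 4, `CC1(C)S[C@@H]2/C(=C\C(=O)c3cc(F)cc(F)c3)C(=O)N2[C@H]1C(=O)OC(c1ccccc1)c1ccccc1`, has not been measured. It differs from compound 1 in one place: 3,5-difluorophenyl in place of 4-(trifluoromethyl)phenyl on a carbonyl carbon. For the measured compounds named here, no measured pair shows this kind of change, so there is no step to lean on; the only guide is that compound 1 itself sits at 15600 nM.

The step that this estimate means, a 1.3-fold higher number from compound 1 to compound 4 (0.11 log units; within the scatter), is expected to be small, with no clear direction beyond the scatter. Compound 4 is therefore expected to give about 20000 nM in this assay, within a range from 7000 nM to 60000 nM.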

Compound 4, half-maximal inhibitory concentration: 17600 nM
The estimate for compound 4 lay 1.1-fold (0.06 log units) above the measured number; the range from low to high includes it.
By their numbers in this assay, from the lowest: compounds 1 and 4 (each within the scatter of the next); then compounds 2 and 3 (each within the scatter of the next).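

For the compounds shown here, this is the first pair in the set that differs in one place only: in this assay, 3,5-difluorophenyl in place of 4-(trifluoromethyl)phenyl on the carbonyl carbon gives a 1.1-fold higher number from compound 1 to compound 4 (0.05 log units; within the scatter). On this read-out, the two groups can therefore stand in for each other at this position with no change that rises above the usual scatter, and neither compound ranks over the other. Nothing else available here bears on why the two read alike.

Going by these compounds, both groups carry fluorine, and the plain phenyl ketone appears only in compound 2, which also differs elsewhere, so what the fluorine contributes stays open. Also open, on these data alone, is how a group of another kind would read here, such as an amine or a carboxylic acid on the phenyl ring, or a pyridine ring replacing it.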